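The compounds below may be only part of what the source reports. "The series", "measured", "known", "first", "only" and "open" are said of these compounds alone.

Values in a functional assay on B16 cells (Mus musculus) for cytotoxicity, read by MTT assay, with a stated time of 48 h; on this read-out higher numbers stand for weaker inhibition and lower numbers for stronger inhibition:
- compound 1 `C=C1CCC[C@]2(C)CCC(c3cn(-c4ccc(OC)cc4)nn3)=CC[C@@]12C`: 209000 nM
- compound 2 `C=C1CCC[C@]2(C)CCC(c3cn(-c4cccc([N+](=O)[O-])c4)nn3)=CC[C@@]12C`: 31700 nM
- compound 3 `C=C1CCC[C@]2(C)CCC(c3cn(-c4ccc(Cl)cc4)nn3)=CC[C@@]12C`: 27200 nM

Compound 3 shares the low end of this small set with compound 2, as a 1.2-fold lower number from compound 2 to compound 3 (0.07 log units; within the scatter) shows. Both stand clear of compound 1, with a 6.6-fold lower number from compound 1 to compound 2 (0.82 log units; beyond the scatter) and a 7.7-fold lower number from compound 1 to compound 3 (0.89 log units; beyond the scatter). The next compound, compound 4 `C=C1CCC[C@]2(C)CCC(c3cn(-c4ccc(C)cc4)nn3)=CC[C@@]12C`, carries methyl in place of chloro on an aromatic carbon, para to a large group: methyl in place of chloro on an aromatic carbon.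

The closest measured change is the swap at this same place between compound 1 and compound 3, a 7.7-fold lower number from compound 1 to compound 3 (0.89 log units; beyond the scatter), a modest step. For the measured compounds named here, no measured compound carries methyl here, so that step serves only as a rough guide to size. Leaving chloro is expected to give a higher number in this assay, but a smaller move than that step. The estimated change is a 2.0-fold higher number from compound 3 to compound 4 (0.31 log units; beyond the scatter). For compound 4 the expected value is 55000 nM, with an estimated range from 20000 nM to 150000 nM.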

Compound 4, half-maximal inhibitory concentration: 57600 nM
Estimate against measurement, compound 4: 1.0-fold (0.02 log units) below, and the stated range covers the measured number.
By their numbers in this assay, from the lowest: compounds 3, 2 and 4 (each within the scatter of the next, the first and the last beyond it); then compound 1.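

In this assay this place on the aromatic ring still separates methyl from chloro (a 2.1-fold higher number from compound 3 to compound 4 (0.33 log units; beyond the scatter)), although the computed comparison gives the two groups the same heavy-atom count and no hydrogen-bond donors or acceptors. Methyl also stands clear of methoxy (a 3.6-fold lower number from compound 1 to compound 4 (0.56 log units; beyond the scatter)), so the three groups at this one place give three separate levels, with methoxy highest, chloro lowest and methyl between them. Across the change of 3-nitrophenyl to 4-methylphenyl, which alters the group's place as well as its identity, the two compounds cannot be told apart (a 1.8-fold higher number from compound 2 to compound 4 (0.26 log units; within the scatter)).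

No supporting evidence bears on why these groups differ. The compounds shown leave open how an amine, a carboxylic acid or a longer chain such as butyl would read at this place.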